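A few compounds are considered here, and "the series" means these few. Any claim that something is new, unique, unknown or untested is made for them only; others in the source may bear on it.

Measured so far: compound 1 `Cc1oc2c3c(ccc2c(=O)c1C)OC[C@H]1[C@@H]3c2c(ccc(C(=O)c3ccccc3)c2O)OC1(C)C` and compound 2 `Cc1coc2c3c(ccc2c1=O)OC[C@H]1[C@@H]3c2c(ccc(C(=O)Cc3ccccc3)c2O)OC1(C)C`.

In a functional assay on MDA-MB-231 cells (Homo sapiens) for cytotoxicity, read by MTT assay (a higher number here means a weaker inhibitor, a lower number a stronger inhibitor), compound 1 gives only a limit, > 100000 nM. In this assay compound 2 likewise gives only a limit, > 100000 nM. Both shown values sit at the limit of > 100000 nM in this assay, at which 2 of the 2 values shown sit, so compound 2 stands at that limit and no number for it is known. Compound 3 `Cc1coc2c3c(ccc2c1=O)OC[C@H]1[C@@H]3c2c(ccc(C(=O)c3ccccc3)c2O)OC1(C)C` differs from compound 2 by phenyl in place of benzyl on a carbonyl carbon, benzylcarbonyl to benzoyl. Going by the values given here, no step between measured compounds is available; for compound 3 the expected step is a number no higher from compound 2 to compound 3 (the limit leaves the size open), nothing beyond the scatter, since compound 1 with the same benzoyl group also sits at > 100000 nM. Compound 3 is estimated at 100000 nM, between 30000 nM and 300000 nM, most likely again reported only as a limit.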

Compound 3, half-maximal inhibitory concentration: 5680 nM
Estimate against measurement, compound 3: 18-fold (1.25 log units) above; the whole stated range lies above it.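

In this assay, phenyl in place of benzyl on a carbonyl carbon gives an at least 17-fold lower number from compound 2 to compound 3 (1.24 log units; beyond the scatter) and shows that this position is not indifferent to the change. Hydrogen in place of methyl on an aromatic carbon gives an at least 17-fold lower number from compound 1 to compound 3 (1.24 log units; beyond the scatter) and shows that the benzoyl group alone is not sufficient, since compound 1 carries it too. Compound 1 and compound 2 each stand at a limit, not a number: the limit of > 100000 nM in this assay, at which 2 of the 3 values shown sit.

From the compounds shown here alone, the true size of both steps stays open. Also open, going by these compounds, is whether an amine or a longer chain on the carbonyl carbon would keep the activity of compound 3.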